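This account rests on a few compounds, and the source may have more. Where it says the series, first, only, none or still open, it means among the compounds named here.

Three compounds have been measured in a physicochemical assay for lipophilicity, measured as octanol-water partition (on this read-out higher numbers stand for higher lipophilicity and lower numbers for lower lipophilicity), so far:

- compound 1 `CCCC1C(C(=O)OCc2ccccn2)=C(C)NC2=C1C(=O)CCC2` gives 2.6
- compound 2 `CC1=C(C(=O)OCc2cccnc2)C(c2cccc(O)c2)C2=C(CCCC2=O)N1` gives 1.21
- compound 3 `CCCC1C(C(=O)OCc2cccnc2)=C(C)NC2=C1C(=O)CCC2` gives 2.23

Compound 1 (2.6) stands highest of the three, and its gaps to the other two lie beyond the scatter. The next candidate is compound 4 `COc1ccc(C2C(C(=O)OCc3ccccn3)=C(C)NC3=C2C(=O)CCC3)cc1`, which has 4-methoxyphenyl in place of propyl on a saturated ring carbon.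

Two measured steps offer some guidance. The one at the same place is large (a number 1.02 log units higher from compound 2 to compound 3 (beyond the scatter)) and puts propyl in place of 3-hydroxyphenyl. It shows that swapping an aromatic group for propyl at this carbon can move the number a long way. However, no measured compound carries 4-methoxyphenyl, so this step cannot simply be carried over. The other step is modest (a number 0.37 log units lower from compound 1 to compound 3 (beyond the scatter)) and concerns pyridin-3-yl in place of pyridin-2-yl. It bears little on this case, since compound 1 and compound 4 both keep pyridin-2-yl.

As a judgement with wide uncertainty, only a small rise is expected in this assay, an estimated a number 0.20 log units higher from compound 1 to compound 4 (within the scatter) in size. For compound 4 the expected value is 2.8 with an estimated range of 2.3 to 3.3 for the coming measurement.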

Compound 4, partition coefficient: 1.9
The estimate for compound 4 lay 0.90 log units above the measured number; the whole stated range lies above it.
By their numbers in this assay, from the lowest: compound 2; then compound 4; then compound 3; then compound 1.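

At this saturated ring carbon, with the pyridin-2-yl ester kept, putting 4-methoxyphenyl in place of propyl gives a number 0.70 log units lower from compound 1 to compound 4 (beyond the scatter) in this assay. The entering group is the larger one, with 8 heavy atoms against 3 and a six-membered aromatic ring, yet the number falls, so in this pair a bigger group does not bring a higher reading. The earlier step of a number 1.02 log units higher from compound 2 to compound 3 (beyond the scatter) concerned 3-hydroxyphenyl and the pyridin-3-yl ester, and it now has a partner pointing the same way: in both pairs that differ at this carbon, the compound with propyl has the higher number, and no compound shown goes against this, though nothing shown accounts for the drop.

The compounds shown leave open how much of the step belongs to the aromatic ring and how much to the methoxy group, which plain phenyl at this carbon would help to separate. They also leave open whether a longer chain such as hexyl would carry the number above that of propyl, and whether 4-methoxyphenyl would give a similar step with the pyridin-3-yl ester.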